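The source may hold more compounds than are shown below. What is called first, only, known or untested is meant among the compounds shown, and "the series" means these compounds.

Compound 1 `O=C(Nc1cccc(C(F)(F)F)c1)N[C@H]1CC[C@H](Oc2cccc(F)c2)CC1` in a functional assay on CRL2813 cells (Homo sapiens) for cytotoxicity, read by sulforhodamine B assay, with a stated time of 5 days (on this read-out lower numbers stand for stronger inhibition and higher numbers for weaker inhibition), gives 2400 nM.
Compound 2 `Cc1ccccc1NC(=O)N[C@H]1CC[C@H](Oc2ccc(F)cc2)CC1` gives > 20000 nM, a limit of the assay rather than a number.
Compound 3 `O=C(Nc1ccccc1C(F)(F)F)N[C@H]1CC[C@H](Oc2ccc(F)cc2)CC1` gives > 20000 nM, also a limit.

Compound 2 thus stands only at a limit, one shared by two of the three values (the limit of > 20000 nM in this assay, at which 2 of the 3 values shown sit). Compound 4 `O=C(Nc1cccc(I)c1)N[C@H]1CC[C@H](Oc2ccc(F)cc2)CC1` differs from compound 2 by 3-iodophenyl in place of 2-methylphenyl on an amide-type nitrogen. Among the compounds with values here, the only measured step on this phenyl, a step that the two limits leave unreadable from compound 2 to compound 3, cannot be read because both ends are limits, so no measured step gives a usable size for this change. Within the data shown here, compound 1 carries a trifluoromethyl instead of the methyl and gives a number, but it also differs in the other ring, so its value shows only that a change here can coincide with measurable inhibition. Compound 4 is therefore expected at 6000 nM, within 1500 nM to 25000 nM, with a fair chance of a limit only. The expected step is an at least 3.3-fold lower number from compound 2 to compound 4 (0.52 log units; beyond the scatter).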

Compound 4, half-maximal inhibitory concentration: 5200 nM
Beside the measured number, compound 4's estimate is 1.2-fold (0.06 log units) above it; measured number inside the range.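

Putting 3-iodophenyl in place of 2-methylphenyl on the amide-type nitrogen gives, in this assay, an at least 3.8-fold lower number from compound 2 to compound 4 (0.58 log units; beyond the scatter). Within the data shown here, this is the first readable step on this phenyl with the rest of the molecule unchanged, as the step from compound 2 to compound 3 cannot be read. The value of compound 2 is a limit, so this step gives only a minimum size: the limit of > 20000 nM in this assay, at which 2 of the 4 values shown sit.

The change replaces the methyl with iodine and also moves the substituent, and the compounds shown do not separate these two differences. Going by these compounds, whether an amine or a carboxylic acid on this phenyl would give a measurable number also remains open.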